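Iodo in place of bromo: working notes on the series

The source may report more compounds than this note shows. Statements on the series, on what has been measured and on what is new or still open speak of the compounds shown alone.

In a functional assay on HEL cells (Homo sapiens) for cytotoxicity (a higher number here means that more compound is tolerated, a lower number that less compound is tolerated), compound 1 (`CCCCCCCCCCc1cc2cn([C@H]3C[C@H](O)[C@@H](CO)O3)c(=O)nc2o1`) gives > 50000 nM, which is a limit and not a number. Compound 2 (`O=c1nc2oc(CCCCCCCCCBr)cc2cn1[C@H]1C[C@H](O)[C@@H](CO)O1`) gives > 50000 nM, also only a limit. Among the compounds with values here, the series so far therefore sits at one value: the limit of > 50000 nM in this assay, at which 2 of the 2 values shown sit. Within the data shown here, the only measured step is a step that the two limits leave unreadable from compound 1 to compound 2, so it offers no size to carry forward.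

Compound 3 (`O=c1nc2oc(CCCCCCCCCI)cc2cn1[C@H]1C[C@H](O)[C@@H](CO)O1`) follows from compound 2 by one change: iodo in place of bromo on a saturated chain carbon, nine bonds along the chain from an aromatic carbon. Among the measured compounds shown here, no measured step covers this exchange of one halogen for another. With the closest evidence being the limit of compound 2 at > 50000 nM, a result at the same limit is expected in this assay, with no direction of change foreseen. The expected step is a step that the limit leaves unreadable from compound 2 to compound 3. For compound 3 the estimated value is 60000 nM, with an expected range of 25000 nM to 150000 nM.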

Compound 3, half-maximal cytotoxic concentration: > 200000 nM
Compound 3 gave a limit, no number; the forecaster's own chance of this, stated with the estimate: 85%; middle value at least 3.3-fold (0.52 log units) away from the limit.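

In this assay compound 3 gives > 200000 nM, a limit and not a number. Its steps from compound 1 and compound 2, which also gave only limits, cannot be read. The compounds shown leave open whether bromo, iodo or methyl at this place changes the half-maximal cytotoxic concentration at all.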